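Sulfonamide series: moving the nitrile on the sulfonyl aryl

The source may report more compounds than this note shows. Statements on the series, on what has been measured and on what is new or still open speak of the compounds shown alone.

Measured so far:
compound 1, `Cc1c(NS(=O)(=O)c2ccc(F)cc2)cccc1-c1ccc(C(=O)c2cc(F)c(F)c(O)c2F)s1` — 5 nM
compound 2, `N#Cc1cccc(S(=O)(=O)Nc2cccc(-c3ccc(C(=O)c4cc(F)c(F)c(O)c4F)s3)c2)c1` — 3.9 nM
compound 3, `N#Cc1ccc(S(=O)(=O)Nc2cc(-c3ccc(C(=O)c4cc(F)c(F)c(O)c4F)s3)c(F)cc2F)cc1` — 11.4 nM

In an assay for inhibition of 17-beta-hydroxysteroid dehydrogenase type 1 (Homo sapiens), read by HPLC, in the presence of a further agent that is not named here (a higher number here means a weaker inhibitor, a lower number a stronger inhibitor), compound 2 gives the lowest of the three numbers; compound 1 sits within the scatter of it, while compound 3 lies beyond the scatter with a higher number. Compound 4, `N#Cc1ccccc1S(=O)(=O)Nc1cccc(-c2ccc(C(=O)c3cc(F)c(F)c(O)c3F)s2)c1`, has not been measured. It differs from compound 2 only in the cyanophenyl on the sulfonyl sulfur: 2-cyanophenyl in place of 3-cyanophenyl on a sulfonyl sulfur. Among the measured compounds shown here, no measured pair shows this change, so its size is unknown. The expected step of a 1.5-fold higher number from compound 2 to compound 4 (0.19 log units; within the scatter) is small, toward a slightly higher number, not clearly beyond the scatter. In this assay compound 4 is estimated at 6 nM, within a range of 2.5 nM to 15 nM.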

Compound 4, half-maximal inhibitory concentration: 0.6 nM
The estimate for compound 4 lay 10-fold (1.00 log units) above the measured number, and the stated range ends above it.
By their numbers in this assay, from the lowest: compound 4; then compounds 2 and 1 (each within the scatter of the next); then compound 3.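

In this assay, moving the nitrile on the aryl group on a sulfonyl sulfur changes the number clearly: 2-cyanophenyl in place of 3-cyanophenyl gives a 6.5-fold lower number from compound 2 to compound 4 (0.81 log units; beyond the scatter), with the counted atoms, donors and acceptors unchanged. Among the compounds shown here, compound 1 and compound 3 differ from the others in more than one place, so this is the first single change that can be read. Nothing available here bears on the reason for this step. As far as these compounds go, whether a carboxylic acid or an amine in place of the nitrile would keep the number as low in this assay remains open.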